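The compounds below may be only part of what the source reports. "The series", "measured", "known", "first", "only" and "open" are said of these compounds alone.

Compound 1 `COc1ncc(-c2ccc3nc(N)nn3c2)cc1NS(=O)(=O)c1ccc(Cl)cc1` and compound 2 `COc1ncc(-c2ccc3nc(N)nn3c2)cc1NS(=O)(=O)c1ccc(C)cc1` are built on one shared core, while compound 3 `COc1ncc(-c2ccn3nc(NC(C)=O)nc3c2)cc1NS(=O)(=O)c1ccc(Cl)cc1` is built on another; the difference between the two cores is not broken down here. Compound 4 `COc1ncc(-c2ccn3nc(NC(C)=O)nc3c2)cc1NS(=O)(=O)c1ccc(C)cc1` has not yet been measured, and the question is what it should give.

In a functional assay on U-87MG ATCC cells (Homo sapiens) for antiproliferative activity, read by MTT assay, with a stated time of 48 h (on this read-out higher numbers stand for weaker inhibition and lower numbers for stronger inhibition), compound 1 gives 3110 nM. In this assay compound 2 gives 2510 nM. The change from compound 1 to compound 2 is a single small swap, (methyl in place of chloro on an aromatic carbon), and it produced a 1.2-fold lower number from compound 1 to compound 2 (0.09 log units; within the scatter). In this assay compound 3 gives 2120 nM, a number that lies within the usual scatter of both compound 1 and compound 2, so no ordering among the three measured compounds can be read from these values.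

Compound 4 differs from compound 3 by methyl in place of chloro on an aromatic carbon. Among the measured compounds shown here, this is the same change as the one between compound 1 and compound 2, now made on the other core. Only one earlier example of this swap exists among these compounds, so the expectation rests on that alone. Because the earlier step was a 1.2-fold lower number from compound 1 to compound 2 (0.09 log units; within the scatter), the step from compound 3 to compound 4 is expected to be of similar size, a 1.1-fold lower number from compound 3 to compound 4 (0.05 log units; within the scatter), and to stay within the scatter. Compound 4 is therefore expected to give about 1900 nM in this assay, with a plausible range from 900 nM to 4000 nM.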

Compound 4, half-maximal inhibitory concentration: 2030 nM
Estimate against measurement, compound 4: 1.1-fold (0.03 log units) below, within the range that was stated.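

In this assay, methyl in place of chloro on the second core gives a 1.0-fold lower number from compound 3 to compound 4 (0.02 log units; within the scatter), so this swap leaves the number about where it was, as it did on the first core. Set side by side, the two steps agree, and nothing separates one core from the other for this change: the same change on two cores in this assay, a 1.2-fold lower number (0.09 log units; within the scatter) from compound 1 to compound 2 and a 1.0-fold lower number (0.02 log units; within the scatter) from compound 3 to compound 4, 1.2-fold (0.07 log units) apart, within the scatter of two such steps

Among the compounds shown here, this shows that, for these two pairs, swapping 4-chlorophenyl for 4-methylphenyl has no effect that can be told from ordinary repeat variation on either core, but it does not show that a change with a clear effect would carry over in the same way, since neither step rises above the scatter and the comparison rests on only two pairs in a single assay.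

The compounds shown carry only chloro or methyl in that place, so it remains open whether a group such as an amine, a carboxylic acid or a longer chain like butyl would shift the number, and whether it would do so equally on both cores. Also open, going by these compounds, is what each part of the difference between the two cores contributes, including the acetyl group carried by the second core.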